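This account rests on a few compounds, and the source may have more. Where it says the series, first, only, none or still open, it means among the compounds named here.

Compound 1 `Fc1ccc(-c2nn3c(NC4CCCC4)cccc3c2-c2ccco2)cc1` and compound 3 `Cc1nc(-c2c(-c3ccc(F)cc3)nn3c(NC4CCCC4)cccc23)co1` carry no result in an ADME assay on Vero cells (Chlorocebus sabaeus) for cytotoxicity; a higher number here means that more compound is tolerated, a lower number that less compound is tolerated: in this assay compound 1 gives "not determined" (no result reported), and compound 3 gives "not determined" (no result reported). Going by the values given here, compound 2 `Nc1nccc(-c2c(-c3ccc(F)cc3)nn3c(NC4CCCC4)cccc23)n1` gives the only number: in this assay compound 2 gives 46000 nM, so it stands alone, with nothing measured to rank it against. Compound 4 `Fc1ccc(-c2nn3c(NC4CCCC4)cccc3c2-c2cn[nH]c2)cc1` remains to be measured. The change from compound 2 to compound 4 is 1H-pyrazol-4-yl in place of 2-aminopyrimidin-4-yl on an aromatic carbon. Among the compounds with values here, no step between two measured compounds is available, so there is no precedent for the size of this move; the expectation is a step no larger than the scatter, in either direction. Compound 4 is expected at 40000 nM, with a range of 15000 nM to 100000 nM. This rests on compound 2 alone, whose value 46000 nM is the only anchor. The estimated step of a 1.2-fold lower number from compound 2 to compound 4 (0.06 log units; within the scatter) is expected to lie within the scatter.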

Compound 4, half-maximal cytotoxic concentration: 10000 nM
Beside the measured number, compound 4's estimate is 4.0-fold (0.60 log units) above it, outside the stated range (below it).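

In this assay, 1H-pyrazol-4-yl in place of 2-aminopyrimidin-4-yl on this aromatic carbon gives a 4.6-fold lower number from compound 2 to compound 4 (0.66 log units; beyond the scatter) and so shows that the group at this position can move the read-out beyond the scatter. The two groups differ in ring size and in hydrogen-bond acceptor count, and this single pair cannot separate the two differences. Nothing available accounts for the step.

Where a phenyl or a pyridin-4-yl group at this carbon would fall relative to compound 2 and compound 4 remains open. Also open, from the compounds shown here alone, is whether the step persists with a group other than 4-fluorophenyl on the neighbouring ring atom.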